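Changing the Chain Amine of Compound 1

This account rests on a few compounds, and the source may have more. Where it says the series, first, only, none or still open, it means among the compounds named here.

Compound 1 `COc1ccc(CNc2nc(N3CCN(C4CCCC4)CC3)c3ncn(CCCN4CCCC4)c3n2)cc1` gives 240 nM in an assay on HEK293 cells for antagonist activity at Toll-like receptor 9 (Homo sapiens), read by spectrophotometry (on this read-out higher numbers stand for weaker inhibition and lower numbers for stronger inhibition), the highest of the three numbers shown. Compound 2 `CCN1CCN(c2nc(NCc3ccc(OC)cc3)nc3c2ncn3CCCN2CCCC2)CC1` gives 80 nM and compound 3 `Fc1ccc(CNc2nc(N3CCN(C4CCCC4)CC3)c3ncn(CCCN4CCCC4)c3n2)cc1` gives 100 nM in this assay. Compound 4 `CCN1CCN(CCCn2cnc3c(N4CCN(C5CCCC5)CC4)nc(NCc4ccc(OC)cc4)nc32)CC1` differs from compound 1 by 4-ethylpiperazin-1-yl in place of pyrrolidin-1-yl on a saturated chain carbon, three bonds along the chain from an aromatic nitrogen. Neither measured step touches that chain: a 3.0-fold lower number from compound 1 to compound 2 (0.48 log units; beyond the scatter) and a 2.4-fold lower number from compound 1 to compound 3 (0.38 log units; beyond the scatter) concern the ring amine and the aromatic ring, each a modest reduction. Going by the values given here, no measured step bears directly on the change made in compound 4, so only a small shift, within or near the scatter, is expected in this assay. Compound 4 is therefore estimated at 200 nM, between 70 nM and 600 nM, which would be a 1.2-fold lower number from compound 1 to compound 4 (0.08 log units; within the scatter).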

Compound 4, half-maximal inhibitory concentration: 120 nM
Compound 4: middle estimate off by 1.7-fold (0.22 log units), on the high side, and the stated range covers the measured number.
By their numbers in this assay, from the lowest: compounds 2, 3, 4 and 1 (each within the scatter of the next, the first and the last beyond it).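

In this assay, going by these compounds alone, replacing 3-(pyrrolidin-1-yl)propyl with 3-(4-ethylpiperazin-1-yl)propyl gives a 2.0-fold lower number from compound 1 to compound 4 (0.30 log units; within the scatter) and offers the first reading at this position. It shows that a six-membered non-aromatic ring with 2 hetero atoms can stand at the chain end in place of the five-membered ring without a shift beyond the scatter. Nothing available gives a reason for this result. Still open, as far as these compounds go, is how this position responds to a carboxylic acid, an amide or a longer chain. Also open, from the compounds shown here alone, is whether 4-ethylpiperazin-1-yl on the chain combines with the ethyl of compound 2 or the fluoro of compound 3.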